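Swapping furan-3-yl for thiophen-2-yl in a thiourea series

A few compounds are considered here, and "the series" means these few. Any claim that something is new, unique, unknown or untested is made for them only; others in the source may bear on it.

Measured compounds:
compound 1 `CCCOC(=O)C1=C(C)NC(=S)NC1c1ccoc1`, 45%
compound 2 `CC1=C(C(=O)OCc2ccccc2)C(c2ccoc2)NC(=S)N1`, 36%

In an assay on membranes from HEK293 cells for displacement of a labelled ligand from adenosine receptor A2b (Homo sapiens), read by scintillation counting, with a stated time of 30 min, tested at 1 uM (a lower number here means less inhibition, a higher number more inhibition at the concentration tested (going by the name of the read-out)), compound 1 gives 45%, and compound 2 gives 36%. Among the measured compounds shown here, compound 2 has the lowest of the two numbers, but its only neighbour, compound 1, differs by a number 9 percentage points lower from compound 1 to compound 2 (within the scatter), which changes only the ester end of the shared core.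

Compound 3 `CC1=C(C(=O)OCc2ccccc2)C(c2cccs2)NC(=S)N1` differs from compound 2 by thiophen-2-yl in place of furan-3-yl on a saturated ring carbon. For the measured compounds named here, no measured step touches this saturated ring carbon, so the one step known, a number 9 percentage points lower from compound 1 to compound 2 (within the scatter), bears on it only in showing that a small change elsewhere moved the number little. With nothing pointing up or down, compound 3 is expected to sit close to compound 2, with an estimated step of a number 2 percentage points higher from compound 2 to compound 3 (within the scatter) and an estimated value of 38%, ranging from 15% to 62%.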

Compound 3, a percentage reported as inhibition, at one concentration (the size of the read-out at that concentration, not a potency): 45%
Beside the measured number, compound 3's estimate is 7 percentage points below it; the range from low to high includes it.
By their numbers in this assay, from the lowest: compounds 2, 1 and 3 (each within the scatter of the next).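

Among the compounds shown here, this is the first measured change at the saturated ring carbon that carries the five-membered aromatic ring: in this assay, thiophen-2-yl in place of furan-3-yl gives a number 9 percentage points higher from compound 2 to compound 3 (within the scatter), so the two groups cannot be told apart here. The swap alters both the hetero atom of the ring, oxygen to sulfur, and the attachment point, so the step on its own could not separate these two changes. No independent measurement is available to help interpret this result.

Furan-2-yl or thiophen-3-yl at this carbon would separate the hetero atom from the attachment point. A saturated group such as cyclohexyl would ask whether this carbon needs an aromatic ring at all, which the compounds shown leave open.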